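The compounds below may be only part of what the source reports. "The series", "measured", "known", "first", "only" and "open" are said of these compounds alone.

Of the compounds shown here, three sharing one core have been measured in a functional assay on NCI-H460 cells (Homo sapiens) for cytotoxicity, read by MTT assay, with a stated time of 72 h; on this read-out higher numbers stand for weaker inhibition and lower numbers for stronger inhibition: compound 1 `O=C(c1ccc(F)cc1)c1cccc(/C=c2\[nH]c(=O)/c(=C/c3nc[nH]c3C3CC3)[nH]c2=O)c1` gives 2.8 nM, compound 2 `Cc1[nH]cnc1/C=c1\[nH]c(=O)/c(=C/c2cccc(C(=O)c3ccc(F)cc3)c2)[nH]c1=O` gives 15.9 nM, and compound 3 `O=c1[nH]/c(=C\c2c[nH]cn2)c(=O)[nH]/c1=C\c1cccc(Oc2ccc(F)cc2)c1` gives 479 nM, the highest number of the three. Compound 4 `O=C(c1ccc(F)cc1)c1cccc(/C=c2\[nH]c(=O)/c(=C/c3c[nH]cn3)[nH]c2=O)c1` departs from compound 3 by one change, (4-fluorophenyl)carbonyl in place of 4-fluorophenoxy on an aromatic carbon. Within the data shown here, no measured step covers this swap directly. Compound 1 and compound 2 carry the incoming group, but each also has a cyclopropyl or methyl that compound 4 lacks, and a 5.7-fold higher number from compound 1 to compound 2 (0.75 log units; beyond the scatter) shows that this group alone can shift the number. A clear drop in this assay is therefore expected, though not as far as compound 2, which gives 15.9 nM. The estimated change is an 8.0-fold lower number from compound 3 to compound 4 (0.90 log units; beyond the scatter). For compound 4 the expected value is 60 nM, with an estimated range of 20 nM to 180 nM.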

Compound 4, half-maximal inhibitory concentration: 278 nM
Beside the measured number, compound 4's estimate is 4.6-fold (0.67 log units) below it, outside the stated range (above it).
By their numbers in this assay, from the lowest: compound 1; then compound 2; then compounds 4 and 3 (each within the scatter of the next).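

In this assay, (4-fluorophenyl)carbonyl in place of 4-fluorophenoxy on its own gives a step within the scatter (a 1.7-fold lower number from compound 3 to compound 4 (0.24 log units; within the scatter)), so this swap does not account for the low numbers of compound 1 and compound 2. Hydrogen in place of methyl gives a 17-fold higher number from compound 2 to compound 4 (1.24 log units; beyond the scatter) and hydrogen in place of cyclopropyl gives a 99-fold higher number from compound 1 to compound 4 (2.00 log units; beyond the scatter), so among these compounds the large steps lie at that other aromatic carbon. Nothing available explains these steps.

From the compounds shown here alone, what an amine or a longer chain at that carbon would do remains open. So does whether the swap stays within the scatter when methyl or cyclopropyl is present.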